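Swapping an Amide for a Urea on the Shared Core

The compounds below may be only part of what the source reports. "The series", "measured", "known", "first", "only" and "open" are said of these compounds alone.

Of the compounds shown here, three built on the same core have been measured in an assay for binding affinity to 5-hydroxytryptamine receptor 1F (Homo sapiens), read by radioligand binding; a lower number here means a stronger inhibitor, a higher number a weaker inhibitor. Compound 1, `CN1CCC(c2c[nH]c3ccc(NC(=O)c4cccc(F)c4)nc23)CC1`, gives 11 nM. Compound 2, `CCN1CC=C(c2c[nH]c3ccc(NC(C)=O)nc23)CC1`, gives 21 nM in this assay, and compound 3, `CN1CCC(c2c[nH]c3ccc(NS(=O)(=O)c4ccc(F)cc4)nc23)CC1`, gives 27 nM. Compound 1 sits at the low end of these three numbers, but the gap to compound 2 is within the usual scatter, and only the gap to compound 3 lies beyond it. Going by the values given here, no pair of these measured compounds differs in a single place, so no measured step can guide the next change directly.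

The unmeasured compound 4, `CN1CCC(c2c[nH]c3ccc(NC(=O)Nc4ccc(F)cc4)nc23)CC1`, differs from compound 1 in one place: (4-fluorophenyl)amino in place of 3-fluorophenyl on a carbonyl carbon. The carbonyl and the amide-type nitrogen beside it are kept, so the link between the core and the fluorophenyl ring is lengthened by one nitrogen, which also brings one additional hydrogen-bond donor, and the fluorine moves from the 3-position to the 4-position of the ring.

Among the compounds with values here, with no measured step of this kind to lean on, the expectation is a small change, in either direction, close to the scatter. Compound 4 is expected to give about 15 nM, in a range from 5 nM to 45 nM, a step of a 1.4-fold higher number from compound 1 to compound 4 (0.13 log units; within the scatter) that is expected to stay near the scatter.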

Compound 4, inhibition constant: 11 nM
Estimate against measurement, compound 4: 1.4-fold (0.13 log units) above; low and high end bracket the measured number.
By their numbers in this assay, from the lowest: compounds 1, 4, 2 and 3 (each within the scatter of the next, the first and the last beyond it).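

In this assay, going by these compounds alone, the first step in this set that changes only one place reads no change at the digits printed from compound 1 to compound 4 (within the scatter), so the position on the carbonyl carbon holds its number when (4-fluorophenyl)amino stands in place of 3-fluorophenyl. The earlier compounds shown here could not show this, since none of them formed a pair differing in one place; here the link to the fluorophenyl ring gains a nitrogen and a hydrogen-bond donor, and the number stays within the scatter. Nothing shown here gives a reason for this flat step.

The step also carries two changes at once, the added nitrogen and the move of the fluorine, and they could have cancelled each other or both had little effect, which this pair alone cannot tell apart. A (3-fluorophenyl)amino group on the same carbonyl carbon would separate the two, while a plain phenylamino group or a longer chain such as 2-phenylethyl would show whether the fluorine matters at all and how much more length this position holds without a step beyond the scatter.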